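Methoxy Placement and Kinase Inhibition in a Shared Core

The compounds below may be only part of what the source reports. "The series", "measured", "known", "first", "only" and "open" are said of these compounds alone.

Measured so far:
compound 1, `COc1cccc(Cn2cnc3sc(-c4ccncc4)cc3c2=O)c1`, 45 nM
compound 2, `COc1cccc(Cn2cnc3sc(-c4ccnc(OC)c4)cc3c2=O)c1`, > 10000 nM
compound 3, `COc1ccc(Cn2cnc3sc(-c4ccnc(N)c4)cc3c2=O)cc1`, 1450 nM

All three were tested in an assay on isolated protein for inhibition of Rho-associated protein kinase 1 (Homo sapiens), read by radiometric assay and 33P incorporation, with a stated time of 40 min, in the presence of a further agent that is not named here; a higher number here means a weaker inhibitor, a lower number a stronger inhibitor. Compound 1 gives 45 nM. For compound 2 the result is a limit of the assay rather than a number, > 10000 nM, and that is the reason the step of an at least 220-fold higher number from compound 1 to compound 2 (2.34 log units; beyond the scatter) can only be given as an at-least figure, because of the limit of > 10000 nM in this assay, at which 1 of the 3 values shown sits. The change behind that step is methoxy in place of hydrogen on an aromatic carbon.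

Compound 3 gives 1450 nM; how its core differs from that of compound 1 is not broken down here.

The compound not yet measured is compound 4, `COc1ccc(Cn2cnc3sc(-c4ccnc(N)c4)cc3c2=O)cc1OC`. It differs from compound 3 by methoxy in place of hydrogen on an aromatic carbon. For the measured compounds named here, this is the same kind of change as the one from compound 1 to compound 2, but not the same: there the methoxy entered a six-membered aromatic ring with one nitrogen, next to the ring nitrogen, whereas here it enters a six-membered aromatic ring of carbon only, ortho to a methoxy group. Going by the values given here, because the only measured example of this kind of change, an at least 220-fold higher number from compound 1 to compound 2 (2.34 log units; beyond the scatter), sat on a different ring, it is a weak guide. The step from compound 3 to compound 4 is estimated at a 2.1-fold higher number from compound 3 to compound 4 (0.32 log units; beyond the scatter), a modest loss. Compound 4 is expected to give about 3000 nM, with a likely range from 900 nM to 10000 nM.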

Compound 4, half-maximal inhibitory concentration: > 10000 nM
Compound 4: no number, only a limit (the forecaster's own chance of this, stated with the estimate: 25%); middle value at least 3.3-fold (0.52 log units) away from the limit.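

In this assay compound 4 gives > 10000 nM, which is a limit of the assay and not a number. Methoxy in place of hydrogen on an aromatic carbon therefore gives a weaker inhibitor here too, with an at least 6.8-fold higher number from compound 3 to compound 4 (0.83 log units; beyond the scatter), so the two available cases point the same way even though the methoxy enters a different ring in each: the same change on two cores in this assay, an at least 220-fold higher number (2.34 log units; beyond the scatter) from compound 1 to compound 2 and an at least 6.8-fold higher number (0.83 log units; beyond the scatter) from compound 3 to compound 4; the limit leaves it open whether they differ This shows that the direction of the change held in both cases, but it does not show how large the change is on either core, and two cases make no rule for the series, so the size seen on one core cannot be carried over to the other: the limit of > 10000 nM in this assay, at which 2 of the 4 values shown sit.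

The compounds shown leave open whether another group at the same place on the ring of carbon only, such as a chlorine atom or a hydroxyl group, would keep the inhibition seen for compound 3. They also leave open how far the two steps really reach, since comparing their sizes would take measured numbers for compound 2 and compound 4 rather than limits.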